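Compound 4: 1-(pyridin-2-yl)ethyl replaces 2-methyl-1,3-benzothiazol-6-yl

The source may hold more compounds than are shown below. What is called first, only, known or untested is meant among the compounds shown, and "the series" means these compounds.

In a functional assay for inhibition, with Homo sapiens as the target (on this read-out lower numbers stand for stronger inhibition and higher numbers for weaker inhibition), compound 1 `CC(C)(C)Sc1c(CC(C)(C)C(=O)O)n(Cc2ccc(Cl)cc2)c2ccc(OCc3ccc4cnccc4n3)cc12` gives 3 nM, compound 2 `CC(C)(C)Sc1c(CC(C)(C)C(=O)O)n(Cc2ccc(Cl)cc2)c2ccc(OCc3nc4ccccc4s3)cc12` gives 3 nM and compound 3 `Cc1nc2ccc(COc3ccc4c(c3)c(SC(C)(C)C)c(CC(C)(C)C(=O)O)n4Cc3ccc(Cl)cc3)cc2s1` gives 6 nM. Compound 3 therefore stands within the scatter of both of the others, and the three cannot be ranked on these numbers.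

The next compound, compound 4 `CC(COc1ccc2c(c1)c(SC(C)(C)C)c(CC(C)(C)C(=O)O)n2Cc1ccc(Cl)cc1)c1ccccn1`, carries 1-(pyridin-2-yl)ethyl in place of 2-methyl-1,3-benzothiazol-6-yl on a saturated chain carbon bound to an oxygen on an aromatic ring.

The relevant evidence is the three group exchanges at this same carbon: no change at the digits printed from compound 1 to compound 2 (within the scatter), a 2.0-fold higher number from compound 1 to compound 3 (0.30 log units; within the scatter) and a 2.0-fold higher number from compound 2 to compound 3 (0.30 log units; within the scatter). All three stay within the scatter, but each one swaps one two-ring group for another. For the measured compounds named here, no measured compound carries a group with a single aromatic ring, so none of these steps tests the present change directly. They show tolerance only among two-ring groups, and the extrapolation is weak.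

A modest loss is expected in this assay, starting from the 6 nM of compound 3. The estimated step is a 2.5-fold higher number from compound 3 to compound 4 (0.40 log units; beyond the scatter), toward weaker inhibition. For compound 4 the estimated value is 15 nM, with an expected range of 4 nM to 60 nM.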

Compound 4, half-maximal inhibitory concentration: 4 nM
Compound 4: middle estimate off by 3.8-fold (0.57 log units), on the high side; the range from low to high includes it.
By their numbers in this assay, from the lowest: compounds 1, 2, 4 and 3 (each within the scatter of the next).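

In this assay, for the compounds shown here, the group 1-(pyridin-2-yl)ethyl, with one six-membered aromatic ring, is the first group at this position that does not hold two aromatic rings, and the read-out stays within the scatter of all three earlier compounds (a 1.5-fold lower number from compound 3 to compound 4 (0.18 log units; within the scatter); a 1.3-fold higher number from compound 2 to compound 4 (0.12 log units; within the scatter); a 1.3-fold higher number from compound 1 to compound 4 (0.12 log units; within the scatter)). On a saturated chain carbon bound to an oxygen on an aromatic ring, the tolerance seen so far among two-ring groups therefore extends to this smaller group, and a second aromatic ring is not needed to keep the read-out in this range for the compounds shown. No measurement on hand accounts for this tolerance.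

Still open, going by these compounds, is whether a plain phenyl, a pyridin-3-yl or a group with no aromatic ring at all, such as a tert-butyl or an open chain ending in an amine or a carboxylic acid, would hold the read-out in the same range at this carbon. All four compounds lie within the scatter of one another, so the compounds shown give no ranking of these groups and mark no limit to what this position accepts.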